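A few compounds are considered here, and "the series" means these few. Any claim that something is new, unique, unknown or untested is made for them only; others in the source may bear on it.

Measured compounds:
compound 1 `C=CC(=O)Nc1cc(Nc2ncc(Cl)c(Nc3ccccc3S(=O)(=O)C(C)C)n2)c(OC)cc1N1CCN(C)CC1` — in a functional assay on NCI-H3122 cells (Homo sapiens) for inhibition, read by CellTiter-Glo, with a stated time of 72 h (a higher number here means a weaker inhibitor of growth, a lower number a stronger inhibitor of growth), compound 1 gives 33 nM
compound 2 `C=CC(=O)Nc1cc(Nc2ncc(Cl)c(Nc3cccc(C(F)(F)F)c3)n2)c(OC)cc1N1CCN(C)CC1` — in this assay compound 2 gives 770 nM
compound 3 `C=CC(=O)Nc1cc(Nc2ncc(Cl)c(Nc3ccc(F)c(Cl)c3)n2)c(OC)cc1N1CCN(C)CC1` — in this assay compound 3 gives 300 nM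

Compound 3 stands second highest of the three numbers: its nearest neighbour is compound 2, the step being a 2.6-fold lower number from compound 2 to compound 3 (0.41 log units; beyond the scatter), and its furthest is compound 1, with a 9.1-fold higher number from compound 1 to compound 3 (0.96 log units; beyond the scatter). Compound 4 `C=CC(=O)Nc1cc(Nc2ncc(Cl)c(Nc3c(F)cccc3F)n2)c(OC)cc1N1CCN(C)CC1` differs from compound 3 by 2,6-difluorophenyl in place of 3-chloro-4-fluorophenyl on a nitrogen on an aromatic ring.

Going by the values given here, two steps bear on this. The large ones, a 23-fold higher number from compound 1 to compound 2 (1.37 log units; beyond the scatter) and a 9.1-fold higher number from compound 1 to compound 3 (0.96 log units; beyond the scatter), both run from the 2-(isopropylsulfonyl)phenyl to a differently substituted phenyl; compound 4 stays on that side of the series. Among the compounds with values here, the one step between two such phenyls, a 2.6-fold lower number from compound 2 to compound 3 (0.41 log units; beyond the scatter), is modest. Moving from 3-chloro-4-fluorophenyl to 2,6-difluorophenyl is therefore expected to give a step of modest size at most in this assay, direction uncertain, plausibly a somewhat higher number; the expected step is a 1.5-fold higher number from compound 3 to compound 4 (0.18 log units; within the scatter). For compound 4 the estimate in this assay is 450 nM, with a range from 120 nM to 1700 nM.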

Compound 4, concentration for 50% growth inhibition: 2900 nM
Compound 4: the middle estimate sits 6.4-fold (0.81 log units) below what was measured; the whole stated range lies below it.
By their numbers in this assay, from the lowest: compound 1; then compound 3; then compound 2; then compound 4.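

In this assay, this position on the nitrogen proves sensitive even among simple halogen-bearing phenyls: replacing 3-chloro-4-fluorophenyl with 2,6-difluorophenyl, with the heavy-atom count unchanged, gives a 9.7-fold higher number from compound 3 to compound 4 (0.99 log units; beyond the scatter). The same group also falls behind 3-(trifluoromethyl)phenyl, with a 3.8-fold higher number from compound 2 to compound 4 (0.58 log units; beyond the scatter), and far behind 2-(isopropylsulfonyl)phenyl, with an 88-fold higher number from compound 1 to compound 4 (1.94 log units; beyond the scatter), so compound 4 is the weakest inhibitor of growth of the four. No measurement available here accounts for this loss.

The compounds shown do not separate the loss of the chlorine from the change in where the fluorines sit. As far as these compounds go, it also remains open how a phenyl bearing a sulfonamide or a primary amine would compare with the 2-(isopropylsulfonyl)phenyl of compound 1.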